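This account rests on a few compounds, and the source may have more. Where it says the series, first, only, none or still open, it means among the compounds named here.

Compound 1 `CS(=O)(=O)c1ccc(C(=O)N2CCC(C(=O)N3CCc4ccccc43)CC2)cc1[N+](=O)[O-]`: > 27000 nM, a limit of the assay.
Compound 2 `CN(Cc1cccc(F)c1)C(=O)CCCNC(=O)c1ccc(S(C)(=O)=O)c([N+](=O)[O-])c1`: > 27000 nM, a limit of the assay.
Compound 3 `CC(C)N(C(=O)CNC(=O)c1ccc(S(C)(=O)=O)c([N+](=O)[O-])c1)C(C)C`: > 27000 nM, a limit of the assay.

In an ADME assay on HepG2 cells (Homo sapiens) for cytotoxicity, read by CellTiter-Glo and ATP content, with a stated time of 72 h (a higher number here means that more compound is needed for the effect, a lower number that less compound is needed), compound 2 gives > 27000 nM, which is a limit and not a number. Among the compounds with values here, the same holds across the set, since (the limit of > 27000 nM in this assay, at which 3 of the 3 values shown sit), so no compound here can be ranked against another. Compound 4 `CS(=O)(=O)c1ccc(C(=O)NCCCC(=O)N2CCCCC2)cc1[N+](=O)[O-]` differs from compound 2 in one place: piperidin-1-yl in place of (3-fluorobenzyl)(methyl)amino on a carbonyl carbon. Within the data shown here, no step between measured compounds is available, and the three limits give no foothold for a direction, so the step from compound 2 to compound 4 in this assay is expected to stay within the scatter. Compound 4 is therefore expected to give 27000 nM, most likely again as a limit, with a range of 13000 nM to 60000 nM; this means an expected step of a number no higher from compound 2 to compound 4 (the limit leaves the size open).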

Compound 4, half-maximal effective concentration: > 27000 nM
Compound 4 ended at the assay's limit (the forecaster's own chance of this, stated with the estimate: 85%); the middle value sits exactly at the limit.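

Compound 2 and compound 4 both end at a limit in this assay, so no step from one to the other can be read: the limit of > 27000 nM in this assay, at which 4 of the 4 values shown sit.

The compounds shown leave open whether piperidin-1-yl and (3-fluorobenzyl)(methyl)amino differ at all in this assay.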